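Fluoro in Place of Methyl on the Aryl Substituent

The source may report more compounds than this note shows. Statements on the series, on what has been measured and on what is new or still open speak of the compounds shown alone.

Of the compounds shown here, three have been measured in a functional assay on DU-145 cells (Homo sapiens) for cytotoxicity, read by MTT assay, with a stated time of 48 h; on this read-out higher numbers stand for weaker inhibition and lower numbers for stronger inhibition. Compound 2 `COC(=O)c1c(-c2cc3ccccc3oc2=O)nn(-c2cccc(C)c2)c1C(=O)OC` gives 35000 nM, the lowest of the three numbers. Compound 3 `CCOC(=O)c1c(-c2cc3ccccc3oc2=O)nn(-c2ccc(C)c(C)c2)c1C(=O)OCC` gives 40000 nM, which lies within the scatter of compound 2. Compound 1 `CCOC(=O)c1c(-c2c(Cl)c3cc(C)ccc3oc2=O)nn(-c2cccc(C)c2)c1C(=O)OCC` gives 103000 nM, beyond the scatter from compound 2. Compound 4 `COC(=O)c1c(-c2cc3ccccc3oc2=O)nn(-c2cccc(F)c2)c1C(=O)OC` differs from compound 2 by fluoro in place of methyl on an aromatic carbon. Within the data shown here, no measured pair shows this same change, so there is nothing among the three to rest its size on. The step of a 1.1-fold higher number from compound 2 to compound 4 (0.06 log units; within the scatter) is expected to stay within the scatter, in no clear direction. Compound 4 is estimated at 40000 nM in this assay, with a range from 15000 nM to 110000 nM.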

Compound 4, half-maximal inhibitory concentration: 37000 nM
For compound 4 the middle estimate is 1.1-fold (0.03 log units) above the measured one; measured number inside the range.
By their numbers in this assay, from the lowest: compounds 2, 4 and 3 (each within the scatter of the next); then compound 1.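

In this assay, among these compounds, the change from 3-methylphenyl to 3-fluorophenyl gives a 1.1-fold higher number from compound 2 to compound 4 (0.02 log units; within the scatter), the only step here between compounds that differ in one place. At this position on the aromatic ring, methyl and fluoro therefore cannot be told apart on this read-out. Nothing available bears on why this is so. Still open, from the compounds shown here alone, is whether a larger change at the same place, such as an amine or a carboxylic acid, would move the number beyond the scatter. Also open, going by these compounds, is whether fluoro in place of methyl would read the same on the core of compound 1.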